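A methoxy group on the phenylethynyl arm of compound 1

A few compounds are considered here, and "the series" means these few. Any claim that something is new, unique, unknown or untested is made for them only; others in the source may bear on it.

Compound 1 `CNC(=O)[C@@]12C[C@@H]1[C@@H](n1cnc3c(NC)nc(C#Cc4ccccc4)nc31)[C@H](O)[C@@H]2O` stands second highest of three measured compounds in an assay on CHO cells for displacement of a labelled ligand from adenosine receptor A1 (Homo sapiens), read by scintillation counting, with a stated time of 60 min, tested at 10 uM (on this read-out lower numbers stand for less inhibition and higher numbers for more inhibition at the one concentration tested (going by the name of the read-out)), where compound 1 gives 18%. Its neighbours are compound 2 `CNC(=O)[C@@]12C[C@@H]1[C@@H](n1cnc3c(NC)nc(C#Cc4ccc(F)cc4)nc31)[C@H](O)[C@@H]2O`, which gives 27%, and compound 3 `CNC(=O)[C@@]12C[C@@H]1[C@@H](n1cnc3c(NC)nc(C#Cc4ccc(Cl)cc4)nc31)[C@H](O)[C@@H]2O`, which gives 13%. The steps of a number 9 percentage points higher from compound 1 to compound 2 (within the scatter) and a number 5 percentage points lower from compound 1 to compound 3 (within the scatter) both lie within the scatter, while a number 14 percentage points lower from compound 2 to compound 3 (beyond the scatter) is a modest one. Compound 4 `CNC(=O)[C@@]12C[C@@H]1[C@@H](n1cnc3c(NC)nc(C#Cc4ccc(OC)cc4)nc31)[C@H](O)[C@@H]2O` differs from compound 1 by methoxy in place of hydrogen on an aromatic carbon. Within the data shown here, no measured step introduces a methoxy group, but the fluoro and chloro changes, each also on an aromatic carbon, stayed within the scatter. For compound 4 no step beyond the scatter is therefore expected, a number 2 percentage points higher from compound 1 to compound 4 (within the scatter). Compound 4 is estimated at 20%, between 5% and 38%.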

Compound 4, a percentage reported as inhibition, at one concentration (the size of the read-out at that concentration, not a potency): 10%
Compound 4: the middle estimate sits 10 percentage points above what was measured; low and high end bracket the measured number.
By their numbers in this assay, from the lowest: compounds 4, 3, 1 and 2 (each within the scatter of the next, the first and the last beyond it).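

In this assay, among these compounds, methoxy, the only group at this place that carries an oxygen, gives a number 8 percentage points lower from compound 1 to compound 4 (within the scatter) and so leaves the number of the unsubstituted compound essentially unmoved. Set against the two halogens, the change reads a number 3 percentage points lower from compound 3 to compound 4 (within the scatter) for chloro and a number 17 percentage points lower from compound 2 to compound 4 (beyond the scatter) for fluoro, so fluoro alone stands apart from methoxy, and only modestly. Nothing at hand explains these numbers. Going by these compounds, whether an amine, a carboxylic acid or a longer alkoxy chain at this place would move the number beyond the scatter from compound 1 remains open.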